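The source may hold more compounds than are shown below. What is called first, only, known or untested is meant among the compounds shown, and "the series" means these compounds.

Working notes on the ester series on the shared core, followed in a functional assay on HeLa cells (Homo sapiens) for cytotoxicity, read by MTT assay; a lower number here means a stronger inhibitor, a higher number a weaker inhibitor. Compound 1 (`CC[C@](C)(O)CC(=O)O[C@H](CC=C(C)C)C1=CC(=O)c2c(O)ccc(O)c2C1=O`) gives 30200 nM, and compound 2 (`CC(C)=CC[C@@H](OC(=O)C1CCCO1)C1=CC(=O)c2c(O)ccc(O)c2C1=O`) gives 17000 nM. These two lie within the scatter of each other, with a 1.8-fold lower number from compound 1 to compound 2 (0.25 log units; within the scatter). Compound 3 (`CC(C)=CC[C@@H](OC(=O)C1CCCCO1)C1=CC(=O)c2c(O)ccc(O)c2C1=O`) gives > 100000 nM, which is a limit of the assay and not a number. Compound 3 therefore stands as the weakest of the three, though without a true value, as shown by an at least 3.3-fold higher number from compound 1 to compound 3 (0.51 log units; beyond the scatter) and by an at least 5.8-fold higher number from compound 2 to compound 3 (0.76 log units; beyond the scatter).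

The next change leads to compound 4 (`CCC(O)(CC)CC(=O)O[C@H](CC=C(C)C)C1=CC(=O)c2c(O)ccc(O)c2C1=O`): 2-ethyl-2-hydroxybutyl in place of oxan-2-yl on a carbonyl carbon. In words, 2-ethyl-2-hydroxybutyl comes in place of oxan-2-yl on a carbonyl carbon. The entering group has no ring, and among the measured groups its name stands closest to the 2-hydroxy-2-methylbutyl of compound 1. The main guide is thus an at least 3.3-fold higher number from compound 1 to compound 3 (0.51 log units; beyond the scatter), read in reverse, with a 1.8-fold lower number from compound 1 to compound 2 (0.25 log units; within the scatter) showing that compound 1 and compound 2 do not separate. A modest or larger step to a lower number in this assay is expected, its exact size open while compound 3 has only a limit. The expected step is an at least 3.5-fold lower number from compound 3 to compound 4 (0.55 log units; beyond the scatter). For compound 4 the estimated value is 28000 nM, with an expected range of 11000 nM to 70000 nM.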

Compound 4, half-maximal inhibitory concentration: 52000 nM
Compound 4: middle estimate off by 1.9-fold (0.27 log units), on the low side; low and high end bracket the measured number.
By their numbers in this assay, from the lowest: compounds 2, 1 and 4 (each within the scatter of the next, the first and the last beyond it). At a limit, above all of these: compound 3.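

In this assay, replacing oxan-2-yl with 2-ethyl-2-hydroxybutyl on the carbonyl carbon gives an at least 1.9-fold lower number from compound 3 to compound 4 (0.28 log units; that floor lies within the scatter), which sets only a floor and not a measured size for this change, since one end of the step is a limit of the assay: the limit of > 100000 nM in this assay, at which 1 of the 4 values shown sits.

Exchanging 2-hydroxy-2-methylbutyl for 2-ethyl-2-hydroxybutyl gives a 1.7-fold higher number from compound 1 to compound 4 (0.24 log units; within the scatter), so these two open-chain hydroxy esters do not separate, and this position tolerates that enlargement of the chain without a readable change. The exchange of oxolan-2-yl for 2-ethyl-2-hydroxybutyl gives a 3.1-fold higher number from compound 2 to compound 4 (0.49 log units; beyond the scatter), the first gap beyond the scatter between two true numbers in the series, although compound 1 lies within the scatter of both and so gives no clean division between ring and open chain.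

From the compounds shown here alone, how far the oxan-2-yl ester lies from the other three remains open while compound 3 has only a limit. Also open, going by these compounds, is how this position responds to an amine or a carboxylic acid on the acyl group, or to a longer chain such as 2-hydroxy-2-propylpentyl.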